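Compound 2 to compound 4: trimming the carboxy side chain

A few compounds are considered here, and "the series" means these few. Any claim that something is new, unique, unknown or untested is made for them only; others in the source may bear on it.

In a functional assay on MCF7 cells (Homo sapiens) for cytotoxicity, read by MTT assay (on this read-out lower numbers stand for stronger inhibition and higher numbers for weaker inhibition), compound 1 (`CCOC(=O)C(C)Oc1c(-c2ccc(OC)cc2)oc2c(CC=C(C)C)c(O)cc(O)c2c1=O`) gives 4700 nM as a measured number. Compound 2 (`COc1ccc(-c2oc3c(CC=C(C)C)c(OC(C)C(=O)O)cc(O)c3c(=O)c2O)cc1`) returns only a limit (> 100000 nM) and no number. Compound 3 (`COc1ccc(-c2oc3c(CC=C(C)C)c(OCCO)cc(O)c3c(=O)c2OCCO)cc1`) likewise returns only a limit (> 100000 nM) and no number. Within the data shown here, the data so far show the limit of > 100000 nM in this assay, at which 2 of the 3 values shown sit, and no measured step.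

Compound 4 (`COc1ccc(-c2oc3c(CC=C(C)C)c(OCC(=O)O)cc(O)c3c(=O)c2O)cc1`) differs from compound 2 in one place (hydrogen in place of methyl on a saturated chain carbon bound to a carbonyl carbon and an oxygen on an aromatic ring): hydrogen in place of methyl on a saturated chain carbon bound to a carbonyl carbon and an oxygen on an aromatic ring, so that 1-carboxyethoxy becomes carboxymethoxy. No change beyond the scatter is expected in this assay, and another reading at the limit is the likely outcome. This expectation rests on compound 2 and its limit (> 100000 nM) alone. The expected step is a number no higher from compound 2 to compound 4 (the limit leaves the size open) and is estimated to be small. In this assay compound 4 is estimated at 100000 nM with an expected range from 30000 nM to 200000 nM as its read-out.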

Compound 4, half-maximal inhibitory concentration: > 100000 nM
Compound 4: no number, only a limit; the forecaster's own chance of this, stated with the estimate: 80%; the middle value sits exactly at the limit.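

No new step can be read from compound 2 to compound 4 in this assay, as each returns only a limit and no number: the limit of > 100000 nM in this assay, at which 3 of the 4 values shown sit. The compounds shown leave open whether 1-carboxyethoxy and carboxymethoxy differ at all on this read-out.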